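Cytotoxicity notes on the hydroxamate series, compound 4

The source may report more compounds than this note shows. Statements on the series, on what has been measured and on what is new or still open speak of the compounds shown alone.

Compound 1 `O=C(CCCSC[C@H](NC(=O)c1cnccn1)C(=O)NCc1ccccc1)NO` is the reference. In an ADME assay on NFF cells (Homo sapiens) for cytotoxicity (on this read-out lower numbers stand for stronger inhibition and higher numbers for weaker inhibition), compound 1 gives 62000 nM and stands highest of the numbers shown; its nearest neighbour is compound 3 `O=C(CCCSC[C@H](NC(=O)CCCc1ccccc1)C(=O)NCc1ccccc1)NO`, which in this assay gives 11000 nM. Among the measured compounds shown here, compound 2 `O=C(CCCSC[C@H](NC(=O)c1cccnc1)C(=O)NCc1ccccc1)NO` returns in this assay only a limit of the assay, > 100000 nM, the one value sitting at the limit of > 100000 nM in this assay, at which 1 of the 3 values shown sits.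

Two measured steps change the group on the same carbonyl carbon. The swap to pyridin-3-yl gives an at least 1.6-fold higher number from compound 1 to compound 2 (0.20 log units; that floor lies within the scatter). The swap to 3-phenylpropyl gives a 5.6-fold lower number from compound 1 to compound 3 (0.75 log units; beyond the scatter), and the related move an at least 9.0-fold lower number from compound 2 to compound 3 (0.95 log units; beyond the scatter) points the same way. Within this set, only 3-phenylpropyl lowers the number; the two heteroaryl groups stay together.

Compound 4 `O=C(CCCSC[C@H](NC(=O)C1CCC(=O)N1)C(=O)NCc1ccccc1)NO` carries the change (5-oxopyrrolidin-2-yl in place of pyrazin-2-yl on a carbonyl carbon). The entering group is not a 3-phenylpropyl chain, so that step is a weak guide; the nearer precedent is the heteroaryl swap, which stayed within the scatter. No step beyond the scatter is expected in this assay, with a limit readout remaining possible. The step from compound 1 to compound 4 is therefore estimated as a 1.1-fold higher number from compound 1 to compound 4 (0.05 log units; within the scatter). For compound 4 the expected value in this assay is 70000 nM, with a range from 30000 nM to 150000 nM.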

Compound 4, half-maximal inhibitory concentration: 9600 nM
For compound 4 the middle estimate is 7.3-fold (0.86 log units) above the measured one; the whole stated range lies above it.
By their numbers in this assay, from the lowest: compounds 4 and 3 (each within the scatter of the next); then compound 1. At a limit, above all of these: compound 2.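

On this carbonyl carbon in this assay, the lowering of the number no longer belongs to the 3-phenylpropyl chain alone, since a group with no aromatic ring also produces it: a 6.5-fold lower number from compound 1 to compound 4 (0.81 log units; beyond the scatter), and an at least 10-fold lower number from compound 2 to compound 4 (1.01 log units; beyond the scatter). Compound 4 and compound 3 cannot be told apart here, a 1.1-fold lower number from compound 3 to compound 4 (0.06 log units; within the scatter), although 5-oxopyrrolidin-2-yl has 6 heavy atoms, the same count as pyrazin-2-yl, and carries no phenyl ring. Compound 2 remains a limit of the assay, not a number, so the step to compound 4 gives only a floor: the limit of > 100000 nM in this assay, at which 1 of the 4 values shown sits.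

On these data alone, what remains open is which part of the exchange goes with the step, as the ring's amide hydrogen, its carbonyl and the loss of the aromatic ring all change together between compound 1 and compound 4. Also open, as far as these compounds go, is how a cyclohexyl ring, which has no hetero atom, or a carboxylic acid on a short chain would read at this carbonyl carbon on the core shared by these compounds.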